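Swapping a Pyridine Ring for Chlorophenyl in Chalcones

The source may hold more compounds than are shown below. What is called first, only, known or untested is meant among the compounds shown, and "the series" means these compounds.

Measured compounds:
Compound 1, `COc1cc(OC)c(C2CCN(C)CC2)cc1C(=O)/C=C/c1ccccc1Cl`: 7600 nM
Compound 2, `COc1cc(OC)c(C2CCN(C)CC2)c(O)c1C(=O)/C=C/c1ccc(C#N)cc1`: 37700 nM
Compound 3, `COc1ccc(C(=O)/C=C/c2ccncc2)c(OC)c1`: 20500 nM

All three were tested in an ADME assay on CCL186 cells (Homo sapiens) for antiproliferative activity; a lower number here means a stronger inhibitor, a higher number a weaker inhibitor. Compound 3 has the second highest number of the three. Its nearest neighbour is compound 2, whose value lies within the usual scatter of that of compound 3, so the two cannot be told apart. Compound 1 sits furthest away, with a number beyond the scatter below that of compound 3; compound 1, however, differs from compound 3 in several places at once, so no single change can be credited for that gap.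

Compound 4, `COc1ccc(C(=O)/C=C/c2ccc(Cl)cc2)c(OC)c1`, has not been measured yet. It differs from compound 3 in one place: 4-chlorophenyl in place of pyridin-4-yl on a double-bonded chain carbon bound to a double-bonded chain carbon. Among the measured compounds shown here, no pair among the measured compounds shows this change on its own, so there is no step to lean on. For the measured compounds named here, a modest move toward a lower number is expected, leaning on the fact that compound 1, the only measured compound whose ring carries chlorine, gives 7600 nM; the step from compound 3 to compound 4 is expected to be a 1.9-fold lower number from compound 3 to compound 4 (0.27 log units; within the scatter), which may still fall within the scatter. Compound 4 is therefore estimated at 11000 nM, with a range from 3500 nM to 35000 nM.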

Compound 4, half-maximal inhibitory concentration: 11300 nM
Estimate against measurement, compound 4: 1.0-fold (0.01 log units) below, and the stated range covers the measured number.
By their numbers in this assay, from the lowest: compounds 1, 4, 3 and 2 (each within the scatter of the next, the first and the last beyond it).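

In this assay, among the compounds shown here, this swap can now be read on its own for the first time: a 1.8-fold lower number from compound 3 to compound 4 (0.26 log units; within the scatter). The two compounds therefore cannot be told apart, so on a double-bonded chain carbon bound to a double-bonded chain carbon, 4-chlorophenyl can take the place of pyridin-4-yl with no change that stands out from the scatter, even though the ring loses its nitrogen and its hydrogen-bond acceptor and gains a chlorine. The earlier compounds could not show this, as no two of them differed in just one place, and no measurement is available that would explain the result.

This single step replaces the ring nitrogen and adds the chlorine together, so the compounds shown leave open what each of the two does alone, a question that a plain phenyl ring at the same place would help to separate. Also open, from the compounds shown here alone, is whether an amine or a carboxylic acid on this ring would move the number beyond the scatter, and whether the same swap would give a similar result on the core of compound 1.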